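Three limits and a biaryl swap in a cytotoxicity assay

This account rests on a few compounds, and the source may have more. Where it says the series, first, only, none or still open, it means among the compounds named here.

Measured so far in a functional assay on HepG2 cells (Homo sapiens) for cytotoxicity, with a stated time of 72 h; a lower number here means that less compound is needed, a higher number that more compound is needed for the effect
Compound 1 `C=C[C@@](C)(/C=C/c1ccc(Nc2ccccc2)cc1)CCC=C(C)C` gives a limit (> 52000 nM)
Compound 2 `C=C[C@@](C)(/C=C/c1ccc(Nc2ccc(OC)cc2)cc1)CCC=C(C)C` gives a limit (> 52000 nM)
Compound 3 `C=C[C@@](C)(/C=C/c1ccc(Nc2ccc(Cl)c(Cl)c2)cc1)CCC=C(C)C` gives a limit (> 52000 nM)

In this assay compound 3 stands only at a limit (> 52000 nM). Compound 4 `C=C[C@@](C)(/C=C/c1ccc(-c2cccc(F)c2)cc1)CCC=C(C)C` carries one change relative to compound 3 (3-fluorophenyl in place of (3,4-dichlorophenyl)amino on an aromatic carbon), namely 3-fluorophenyl in place of (3,4-dichlorophenyl)amino on an aromatic carbon. Among the measured compounds shown here, three measured steps bear on this change (a step that the two limits leave unreadable from compound 1 to compound 2; a step that the two limits leave unreadable from compound 1 to compound 3; a step that the two limits leave unreadable from compound 2 to compound 3), and none of them has a readable size. All three keep the nitrogen on the aromatic ring, which compound 4 no longer has, so the series does not test this change directly. What compound 1, compound 2 and compound 3 share is the limit of > 52000 nM in this assay, at which 3 of the 3 values shown sit, and on that basis no step beyond the scatter is expected in this assay in either direction. Compound 4 may well return only a limit too. The estimated step is a number no higher from compound 3 to compound 4 (the limit leaves the size open) and it remains uncertain. Compound 4 is estimated at 52000 nM (expected range 15000 nM to 100000 nM).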

Compound 4, half-maximal effective concentration: > 52000 nM
Compound 4: only a limit was reported; the forecaster's own chance of this, stated with the estimate: 75%; the middle value sits exactly at the limit.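

In this assay compound 4 returns only a limit, > 52000 nM. Its steps from compound 1, compound 2 and compound 3 cannot be read, so no new step emerges: the limit of > 52000 nM in this assay, at which 4 of the 4 values shown sit.

The compounds shown leave open what concentration, if any, gives the half-maximal effect for any of the four in this assay.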